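Adding a Hydroxyl to a Chlorophenyl Chalcone

This account rests on a few compounds, and the source may have more. Where it says the series, first, only, none or still open, it means among the compounds named here.

Measured compounds and their values in a functional assay on K562 cells (Homo sapiens) for antiproliferative activity, read by MTT assay, with a stated time of 24 h; on this read-out lower numbers stand for stronger inhibition and higher numbers for weaker inhibition:
compound 1, `COc1ccc(C(=O)/C=C/c2ccsc2)c2c1C=CC(C)(C)O2`: > 10000 nM (a limit of the assay, not a number)
compound 2, `COc1ccc(C(=O)/C=C/c2ccccn2)c2c1C=CC(C)(C)O2`: 5400 nM
compound 3, `COc1ccc(C(=O)/C=C/c2ccc(Cl)cc2)c2c1C=CC(C)(C)O2`: > 10000 nM (a limit of the assay, not a number)

Compound 3 stands at the assay's upper limit, (the limit of > 10000 nM in this assay, at which 2 of the 3 values shown sit), so no number is known for it. Compound 4, `COc1ccc(C(=O)/C=C/c2cc(Cl)ccc2O)c2c1C=CC(C)(C)O2`, differs from compound 3 in one place: 5-chloro-2-hydroxyphenyl in place of 4-chlorophenyl on a double-bonded chain carbon bound to a double-bonded chain carbon.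

The measured steps give little guidance. an at least 1.8-fold lower number from compound 1 to compound 2 (0.26 log units; that floor lies within the scatter) and an at least 1.8-fold higher number from compound 2 to compound 3 (0.26 log units; that floor lies within the scatter) are both floors that lie within the scatter, and a step that the two limits leave unreadable from compound 1 to compound 3 cannot be read at all. Among the compounds with values here, none of them adds or removes a hydroxyl, so no measured step speaks to the change from compound 3 to compound 4. The expected step, a step that the limit leaves unreadable from compound 3 to compound 4, is therefore none beyond the scatter. Compound 4 is estimated to give about 12000 nM in this assay. For compound 4 the expected range runs from 4000 nM to 40000 nM, and a limit rather than a number is the most likely outcome.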

Compound 4, half-maximal inhibitory concentration: 5510 nM
Compound 4: the middle estimate sits 2.2-fold (0.34 log units) above what was measured; measured number inside the range.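

With 5-chloro-2-hydroxyphenyl on the double-bonded chain carbon, a chlorine-bearing aromatic ring now gives a readable number in this assay, but the change from 4-chlorophenyl is only a floor, an at least 1.8-fold lower number from compound 3 to compound 4 (0.25 log units; that floor lies within the scatter), and compound 3 remains a limit of the assay, not a number: the limit of > 10000 nM in this assay, at which 2 of the 4 values shown sit.

Measured against the thiophen-3-yl group, the result is again only a floor: an at least 1.8-fold lower number from compound 1 to compound 4 (0.25 log units; that floor lies within the scatter). Against the pyridin-2-yl group, the result is a 1.0-fold higher number from compound 2 to compound 4 (0.01 log units; within the scatter), so these two groups cannot be told apart in this assay.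

The compounds shown cannot separate the effect of adding the hydroxyl from that of having 5-chloro rather than 4-chloro, as both changes arrive together. They also leave open how an amine or a carboxylic acid in place of that hydroxyl would read out.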